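Methyl to methoxy on compound 2

A few compounds are considered here, and "the series" means these few. Any claim that something is new, unique, unknown or untested is made for them only; others in the source may bear on it.

In a functional assay on U-937 cells (Homo sapiens) for activation, read by flow cytometry, with a stated time of 4 days (a higher number here means that more compound is needed for the effect, a lower number that less compound is needed), compound 1 `O=C(O)c1cccnc1Nc1ccc(OC(F)(F)F)cc1` gives 5600 nM and compound 2 `Cc1ccc(C(=O)NCCC(=O)N[C@@H]2CCCc3ccccc32)cc1` gives 4200 nM so the two numbers sit within the scatter of each other. Compound 3 `COc1ccc(C(=O)NCCC(=O)N[C@@H]2CCCc3ccccc32)cc1` carries methoxy in place of methyl on an aromatic carbon at the place para to a large group. Among the compounds with values here, no measured pair shows this change, so the basis for any forecast is thin. The expected 1.1-fold lower number from compound 2 to compound 3 (0.02 log units; within the scatter) in this assay stays within the scatter, with no direction favoured. For compound 3 the estimated value is 4000 nM (expected range 1500 nM to 11000 nM).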

Compound 3, half-maximal effective concentration: 12000 nM
Beside the measured number, compound 3's estimate is 3.0-fold (0.48 log units) below it; the measured number lies above the stated range.
By their numbers in this assay, from the lowest: compounds 2 and 1 (each within the scatter of the next); then compound 3.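

In this assay, the place para to a large group proves sensitive to this change: methoxy in place of methyl gives a 2.9-fold higher number from compound 2 to compound 3 (0.46 log units; beyond the scatter) and so falls beyond the scatter. Within the data shown here, this is the first single-place step, and it favours 4-methylphenyl over 4-methoxyphenyl at this position. Nothing measured bears on the reason for this step.

Still open, on these data alone, is whether an amine, a hydroxyl or a chlorine at this place would track with methyl or with methoxy. A single step also leaves open whether the same change behaves alike on another core.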